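The compounds below may be only part of what the source reports. "The series", "measured", "known", "first", "only" and "open" are said of these compounds alone.

Working notes on the series. The shared core carries an octyl-substituted aryl ether linked through a ketone to a five-membered aromatic ring with four nitrogen atoms, and the variable group sits on the aromatic carbon of that ring. Compound 1 `CCCCCCCCc1ccc(OCC(=O)Cn2nnc(-c3ccccc3Cl)n2)cc1` gives 32 nM in an assay on microsomes from brain for inhibition of Fatty-acid amide hydrolase 1 (Rattus norvegicus), read by fluorescence and HPLC, with a stated time of 60 min; a higher number here means a weaker inhibitor, a lower number a stronger inhibitor. Compound 2 `CCCCCCCCc1ccc(OCC(=O)Cn2nnc(-c3cccc(S(=O)(=O)N(C)C)c3)n2)cc1` gives 420 nM in this assay, and compound 3 `CCCCCCCCc1ccc(OCC(=O)Cn2nnc(-c3ccncc3)n2)cc1` gives 24 nM.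

Compound 3 stands at the low end of the three numbers: compound 1 sits beside it, a 1.3-fold lower number from compound 1 to compound 3 (0.12 log units; within the scatter), while compound 2 is far off, an 18-fold lower number from compound 2 to compound 3 (1.24 log units; beyond the scatter). The one large move in the set is a 13-fold higher number from compound 1 to compound 2 (1.12 log units; beyond the scatter).

Compound 4 `CCCCCCCCc1ccc(OCC(=O)Cn2nnc(-c3cccnc3)n2)cc1` is not yet measured. Against compound 3 the change is pyridin-3-yl in place of pyridin-4-yl on an aromatic carbon. Going by the values given here, no measured step swaps one pyridinyl for another, so the only guide is the small move from 2-chlorophenyl to pyridin-4-yl and the large move to 3-(dimethylsulfamoyl)phenyl, which is not the change here. Since the two groups count the same atoms and acceptors, no step beyond the scatter is expected in this assay, estimated as a 1.3-fold higher number from compound 3 to compound 4 (0.10 log units; within the scatter). For compound 4 the expected value is 30 nM, between 12 nM and 80 nM.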

Compound 4, half-maximal inhibitory concentration: 23 nM
The estimate for compound 4 lay 1.3-fold (0.12 log units) above the measured number, and the stated range covers the measured number.
By their numbers in this assay, from the lowest: compounds 4, 3 and 1 (each within the scatter of the next); then compound 2.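

Pyridin-3-yl in place of pyridin-4-yl on this aromatic carbon is the first swap of one pyridinyl for another, and it gives a step within the scatter in this assay (a 1.0-fold lower number from compound 3 to compound 4 (0.02 log units; within the scatter)), so these two groups, with the same counted atoms and acceptors, are not told apart at this place. The pyridin-3-yl group also stays level with 2-chlorophenyl (a 1.4-fold lower number from compound 1 to compound 4 (0.14 log units; within the scatter)) and shows the same large gap to 3-(dimethylsulfamoyl)phenyl (an 18-fold lower number from compound 2 to compound 4 (1.26 log units; beyond the scatter)), so the 3-(dimethylsulfamoyl)phenyl group remains the only one of the four set apart by a step beyond the scatter. Nothing measured at hand speaks to the reason for this result.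

Open, as far as these compounds go, is how pyridin-2-yl, plain phenyl, or a phenyl carrying an amine or a carboxylic acid would compare on this carbon. Also open, from the compounds shown here alone, is which part of the 3-(dimethylsulfamoyl)phenyl group goes with the large steps, and whether the level result among the other three groups holds with a shorter chain in place of octyl.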